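Cyclopropyl amides on the shared core: methyl for fluorine

A few compounds are considered here, and "the series" means these few. Any claim that something is new, unique, unknown or untested is made for them only; others in the source may bear on it.

Three amides on the shared core have been run in an assay on CHO cells for agonist activity at Neuronal acetylcholine receptor; alpha3/alpha6/beta2/beta3 (Homo sapiens), read by FLIPR and calcium flux; a higher number here means a larger maximal response, a lower number a smaller maximal response. Compound 1 `CCCC(=O)N1CC2CC(C1)N2` gives 92% in this assay; compound 2 `O=C(C1CC=CC1)N1CC2CC(C1)N2` gives 99%; compound 3 `O=C([C@@H]1C[C@@H]1F)N1CC2CC(C1)N2` gives 120% and stands highest of the three, above compound 2 and compound 1 by gaps beyond the scatter. Among the compounds with values here, the one step between single-point neighbours is a number 28 percentage points higher from compound 1 to compound 3 (beyond the scatter), a modest rise in this assay.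

Compound 4 `C[C@@H]1C[C@H]1C(=O)N1CC2CC(C1)N2` is not yet measured. Against compound 3 it differs as follows: 2-methylcyclopropyl in place of 2-fluorocyclopropyl on a carbonyl carbon. The carbonyl carbon and the ring size are kept; only the substituent on the three-membered ring changes.

Within the data shown here, no measured step isolates this change. The step from compound 1 to compound 3 swaps a chain for a substituted three-membered ring, and the values of compound 2 and compound 3 compare a larger ring with the fluorinated small ring; neither separates fluorine from methyl on that ring. Since both small-ring and larger-ring amides sit high in this assay, compound 4 is expected to stay in that region, with a number 15 percentage points lower from compound 3 to compound 4 (beyond the scatter) as the expected step, most likely within or only just beyond the scatter. Compound 4 is therefore estimated at 105% in this assay, in a range from 85% to 125%.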

Compound 4, largest response reached (Emax), in percent of the reference or control that the assay uses: 110%
Estimate against measurement, compound 4: 5 percentage points below; low and high end bracket the measured number.
By their numbers in this assay, from the lowest: compounds 1 and 2 (each within the scatter of the next); then compounds 4 and 3 (each within the scatter of the next).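

In this assay the change on the carbonyl carbon to 2-methylcyclopropyl in place of 2-fluorocyclopropyl gives a number 10 percentage points lower from compound 3 to compound 4 (within the scatter) and so cannot be told apart from scatter; at this position, a high response does not depend on the fluorine. Set against the propyl amide, the same all-carbon ring gives a number 18 percentage points higher from compound 1 to compound 4 (beyond the scatter) and is a modest rise, so a substituted three-membered ring need not carry fluorine to stand clear of the propyl chain, as a number 28 percentage points higher from compound 1 to compound 3 (beyond the scatter) alone could not show. Nothing measured on these compounds bears on why the two ring substituents read alike.

Open, on these data alone, is whether an unsubstituted cyclopropyl ring, or a 2-ethyl or 2-trifluoromethyl group on the ring, would stay in the same range in this assay or fall towards compound 1. Also open, as far as these compounds go, is whether the mirror-image arrangement of the two defined stereocentres would keep the response seen for compound 3 and compound 4, or whether a ring amine or a carboxylic acid would be tolerated there.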